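A Bromine Swap on a Weak Inhibitor

A few compounds are considered here, and "the series" means these few. Any claim that something is new, unique, unknown or untested is made for them only; others in the source may bear on it.

In an ADME assay on HepG2 cells (Homo sapiens) for inhibition, read by fluorescence and resazurin assay, with a stated time of 72 h (on this read-out higher numbers stand for weaker inhibition and lower numbers for stronger inhibition), compound 1 (`Cc1c2ccc(Nc3ccnc(Nc4cccc(S(N)(=O)=O)c4)n3)cc2nn1C`) gives 19000 nM and compound 2 (`Cc1cccc(Nc2nccc(Nc3ccc4cn[nH]c4c3)n2)c1`) gives 15000 nM as its value, so these two compounds lie within the usual scatter of each other. Compound 3 (`O=C(O)c1ccc(Nc2nccc(Nc3ccc4nc[nH]c4c3)n2)cc1`) is reported only as a limit (> 25000 nM). Compound 4 (`Brc1ccc(Nc2nccc(Nc3ccc4cn[nH]c4c3)n2)cc1`) carries 4-bromophenyl in place of the 3-methylphenyl of compound 2 on a nitrogen on an aromatic ring (4-bromophenyl in place of 3-methylphenyl on a nitrogen on an aromatic ring). Among the compounds with values here, no measured pair shows this kind of swap, so in this assay no step beyond the scatter is expected, with only a slight lean toward stronger inhibition. The expected change runs a 1.5-fold lower number from compound 2 to compound 4 (0.18 log units; within the scatter) as a rough guide. For compound 4 the estimated value is 10000 nM (expected range 4000 nM to 25000 nM).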

Compound 4, half-maximal inhibitory concentration: 20000 nM
Compound 4: the middle estimate sits 2.0-fold (0.30 log units) below what was measured; low and high end bracket the measured number.
By their numbers in this assay, from the lowest: compounds 2, 1 and 4 (each within the scatter of the next). At a limit, above all of these: compound 3.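

In this assay, changing 3-methylphenyl to 4-bromophenyl on this nitrogen gives a 1.3-fold higher number from compound 2 to compound 4 (0.12 log units; within the scatter), so this first pair differing in one place shows no readable effect of the swap. Neither group brings stronger inhibition here, and both compounds remain close to the highest number the assay reports: the limit of > 25000 nM in this assay, at which 1 of the 4 values shown sits.

This single pair cannot show whether any change at this position matters in this assay. On these data alone, whether an amine or a longer chain in this place would give a step beyond the scatter stays open.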